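The compounds below may be only part of what the source reports. "The series", "measured", "known", "first", "only" and "open" are said of these compounds alone.

Compound 1 `CC(C)c1ccc(Cn2cncc2CNc2ccc(-c3nc4ccccc4s3)c(-c3ccccc3)c2)cc1`, compound 2 `COC(=O)c1ccc(NCc2cncn2Cc2ccccc2OC)cc1-c1ccccc1` and compound 3 `Cc1ccccc1-c1cc(NCc2cncn2Cc2ccc(-c3ccccc3)cc2)ccc1-c1nc2ccccc2s1` belong to one series that was examined in a toxicity assay on NIH3T3 cells (Mus musculus) for cytotoxicity, read by resazurin assay; on this read-out lower numbers stand for an effect already at smaller amounts and higher numbers for an effect only at larger amounts of compound. In this assay compound 1 reaches only the limit of the measurement, > 1000 nM, and not a number. Compound 3 likewise stops at a limit in this assay, > 1000 nM. For compound 2 the outcome in this assay is "not determined" (no result reported), so compound 2 stands without a value among the numbers shown. What is known of the series is carried by the other two compounds, both sitting at the limit described as the limit of > 1000 nM in this assay, at which 2 of the 3 values shown sit.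

Compound 4 `COC(=O)c1ccc(NCc2cncn2Cc2ccc(Cl)cc2)cc1-c1ccccc1` has not yet been measured in this assay. It differs from compound 2 in one place: 4-chlorophenyl in place of 2-methoxyphenyl on a saturated chain carbon bound to an aromatic nitrogen. Going by the values given here, no measured step between two compounds of this kind is available, so no size for this step can be read from the data; in this assay he expects at most a small step, none beyond the scatter, and in either direction. Because the two values available sit at the limit of > 1000 nM in this assay, at which 2 of the 3 values shown sit, he expects compound 4 to show an effect in this assay only at larger amounts, with an estimate of 3000 nM, ranging from 800 nM to 15000 nM.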

Compound 4, half-maximal effective concentration: 25000 nM
The estimate for compound 4 lay 8.3-fold (0.92 log units) below the measured number; the measured number lies above the stated range.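

No new step can be read, as compound 2 carries no number in this assay and so its pair with compound 4 gives no size. The compounds shown leave open what the change from 2-methoxybenzyl to 4-chlorobenzyl does on its own in this assay, where the series still rests largely on one limit: the limit of > 1000 nM in this assay, at which 2 of the 4 values shown sit.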